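Methoxy in place of methylsulfanyl: cytotoxicity notes

The source may hold more compounds than are shown below. What is called first, only, known or untested is meant among the compounds shown, and "the series" means these compounds.

Compound 1, `Fc1cccc(F)c1Cc1cnc(Nc2ccc(CCOc3ccncc3)cc2)o1`: 11000 nM
Compound 2, `O=c1ncccn1SCCc1ccc(Nc2ncc(Cc3c(F)cccc3F)o2)cc1`: > 100000 nM (a limit)
Compound 3, `CSCc1ccc(Nc2ncc(Cc3c(F)cccc3F)o2)cc1`: > 100000 nM (a limit)

In an ADME assay on MT2 cells (Homo sapiens) for cytotoxicity, read by MTT assay (on this read-out higher numbers stand for lower toxicity in this test and lower numbers for higher toxicity in this test), compound 1 gives 11000 nM. For compound 2 the value > 100000 nM is a limit of the assay, not a number. For compound 3 the value > 100000 nM is likewise a limit; compound 3 thus stands at the limit, as described by the limit of > 100000 nM in this assay, at which 2 of the 3 values shown sit. The measured steps are an at least 9.0-fold higher number from compound 1 to compound 3 (0.95 log units; beyond the scatter), an at least 9.0-fold higher number from compound 1 to compound 2 (0.95 log units; beyond the scatter) and a step that the two limits leave unreadable from compound 2 to compound 3. Compound 4, `COCc1ccc(Nc2ncc(Cc3c(F)cccc3F)o2)cc1`, differs from compound 3 by methoxy in place of methylsulfanyl on a saturated chain carbon bound to an aromatic carbon. Going by the values given here, no measured step exchanges one such small group for another at this position, so the steps bear only loosely on it; the expectation is no step beyond the scatter. Compound 4 is therefore expected near 100000 nM, between 30000 nM and 300000 nM, meaning an expected a number no higher from compound 3 to compound 4 (the limit leaves the size open), most likely again reported only as a limit.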

Compound 4, half-maximal cytotoxic concentration: 32000 nM
Compound 4: the middle estimate sits 3.1-fold (0.49 log units) above what was measured; low and high end bracket the measured number.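

The exchange of methylsulfanyl for methoxy is not silent at this position: in this assay it gives an at least 3.1-fold lower number from compound 3 to compound 4 (0.49 log units; beyond the scatter). Set against the larger group of compound 2, the same methoxy gives an at least 3.1-fold lower number from compound 2 to compound 4 (0.49 log units; beyond the scatter). Against the ((pyridin-4-yl)oxy)methyl of compound 1 it gives a 2.9-fold higher number from compound 1 to compound 4 (0.46 log units; beyond the scatter), so small groups here need not all reach the limit of the assay.

From the compounds shown here alone, the values of compound 2 and compound 3 are limits, so the full size of these two lower steps stays open. Where an amine, a carboxylic acid or a longer chain would fall at this position also stays open.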